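Compound 4: 4-Acetylphenoxy in Place of Bromo

This account rests on a few compounds, and the source may have more. Where it says the series, first, only, none or still open, it means among the compounds named here.

Three compounds have so far been measured in a functional assay on the whole organism (strain albino) for inhibition, with Rattus norvegicus as the target, read by paw edema, with stated times of 30 min and 5 h, at a dose of 100 mg/kg by the oral route; a higher number here means more inhibition at the dose given (going by the name of the read-out), a lower number less inhibition:

compound 1, `Nc1ccc(C(=O)/C=C/c2ccc(Cl)cc2)cc1`, gives 54%
compound 2, `O=C(CBr)Nc1ccc(C(=O)/C=C/c2ccc(Cl)cc2)cc1`, gives 54%
compound 3, `CC(Br)C(=O)Nc1ccc(C(=O)/C=C/c2ccc(Cl)cc2)cc1`, gives 50%

Compound 2 stands level with compound 1, the two together the highest of the three numbers; its nearest neighbour is compound 1, with no change at the digits printed from compound 1 to compound 2 (within the scatter), and its furthest is compound 3, with a number 4 percentage points lower from compound 2 to compound 3 (within the scatter). Compound 4, `CC(=O)c1ccc(OCC(=O)Nc2ccc(C(=O)/C=C/c3ccc(Cl)cc3)cc2)cc1`, differs from compound 2 in one place: 4-acetylphenoxy in place of bromo on a saturated chain carbon bound to a carbonyl carbon. Among the measured compounds shown here, the only measured step that touches this same saturated chain carbon is a number 4 percentage points lower from compound 2 to compound 3 (within the scatter), and the two steps from compound 1, no change at the digits printed from compound 1 to compound 2 (within the scatter) and a number 4 percentage points lower from compound 1 to compound 3 (within the scatter), were likewise within the scatter. For the measured compounds named here, no measured step replaces the bromo itself, so nothing in the numbers points in either direction. Compound 4 is therefore expected to show a step of a number 2 percentage points lower from compound 2 to compound 4 (within the scatter), none beyond the scatter. The estimate for compound 4 is 52%, between 38% and 66%.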

Compound 4, a percentage reported as inhibition, in the whole organism at one dose (the size of the read-out at that dose, not a potency): 55%
Estimate against measurement, compound 4: 3 percentage points below, within the range that was stated.
By their numbers in this assay, from the lowest: compounds 3, 1, 2 and 4 (each within the scatter of the next).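

The step of a number 1 percentage points higher from compound 2 to compound 4 (within the scatter) shows, in this assay, that this saturated chain carbon bound to a carbonyl carbon can carry 4-acetylphenoxy instead of bromo with the read-out staying within the scatter. The earlier steps shown here had changed this carbon only by a methyl, whereas this change brings in 10 heavy atoms and a six-membered aromatic ring in place of a single bromine. No measured evidence accounts for this result. Open, going by these compounds, is how plain phenoxy, without the acetyl, would read at this carbon, and how an amine or a carboxylic acid would read there.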